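Methoxy for methyl on the benzoxazole-bearing series: compound 4

The source may report more compounds than this note shows. Statements on the series, on what has been measured and on what is new or still open speak of the compounds shown alone.

Among the measured compounds shown here, compound 1 `Cc1cccc2nc(N3CCN(C)CC3)oc12` is one of three compounds measured in a functional assay on ileum (strain Hartley) for agonist activity at 5-hydroxytryptamine receptor 3A (Cavia porcellus); a lower number here means a less potent compound, a higher number a more potent compound, by a factor of ten per unit of this negative logarithm. In this assay compound 1 gives 5.48, the lowest of the three numbers. Compound 3 `CN1CCN(c2nc3cc(F)ccc3o2)CC1` gives 5.57, a number within the scatter of that of compound 1, so the two cannot be told apart. For the measured compounds named here, compound 2 `CCc1cc(C)cc2nc(N3CCN(C)CC3)oc12` gives 6.46, a number beyond the scatter above that of compound 1; with two groups changed at once, no single step connects it to compound 1.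

Compound 4 `COc1cccc2nc(N3CCN(C)CC3)oc12` differs from compound 1 in one place: methoxy in place of methyl on an aromatic carbon. The change keeps the heavy-atom count small and adds one hydrogen-bond acceptor, as counted. Going by the values given here, no measured pair in this set shows what this exchange does in this assay, so nothing here points firmly in either direction.

The expectation is that compound 4 will sit close to compound 1, with the step from compound 1 to compound 4 estimated at a number 0.12 log units higher from compound 1 to compound 4 (within the scatter), no larger than the scatter. Compound 4 is therefore estimated at 5.6, in the range 5 to 6.2.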

Compound 4, negative logarithm of the half-maximal effective concentration: < 4
Compound 4: a limit, no number; the forecaster's own chance of this, stated with the estimate: 5%; at least 1.60 log units between middle value and limit.
By their numbers in this assay, from the lowest: compounds 1 and 3 (each within the scatter of the next); then compound 2. At a limit, below all of these: compound 4.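

In this assay compound 4 gives < 4, which is a limit of the assay and not a number: the limit of < 4 in this assay, at which 1 of the 4 values shown sits.

Methoxy in place of methyl on this aromatic carbon gives a number at least 1.48 log units lower from compound 1 to compound 4 (beyond the scatter), the first step in the series that changes a single place. It shows that this carbon does not accept every small group alike: with methyl, compound 1 keeps a measurable value, and with methoxy, compound 4 does not.

Going by these compounds, how far the true value of compound 4 lies past the limit remains open, so the full size of the step is unknown. Also open, on these data alone, is whether chlorine, a hydroxyl or an amine on the same carbon would keep a value close to that of compound 1 or lose it as methoxy does.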